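From 4-methylphenyl to 4-methoxyphenyl

This account rests on a few compounds, and the source may have more. Where it says the series, first, only, none or still open, it means among the compounds named here.

Measured so far in a functional assay on OVCAR-3 cells (Homo sapiens) for inhibition, read by sulforhodamine B assay, with a stated time of 48 h (a higher number here means a weaker inhibitor of growth, a lower number a stronger inhibitor of growth), for three compounds:
compound 1 `CC(C)(C)NCc1c(C(=O)O)nn(-c2ccccc2)c1-c1ccc(Cl)cc1` gives > 652000 nM as a limit
compound 2 `CC(C)(C)NCc1c(C(=O)O)nn(-c2ccccc2)c1-c1ccc(Br)cc1` gives > 585000 nM as a limit
compound 3 `Cc1ccc(-c2c(CNC(C)(C)C)c(C(=O)O)nn2-c2ccccc2)cc1` gives 283000 nM as a true number

Among the compounds with values here, compound 3 holds the only true number of the three, and it is the lowest reading so far. Compound 4 `COc1ccc(-c2c(CNC(C)(C)C)c(C(=O)O)nn2-c2ccccc2)cc1` carries methoxy in place of methyl on the aromatic carbon para to a large group methoxy in place of methyl on an aromatic carbon with all else unchanged. Within the data shown here, two measured steps concern that same carbon, namely an at least 2.3-fold lower number from compound 1 to compound 3 (0.36 log units; beyond the scatter) and an at least 2.0-fold lower number from compound 2 to compound 3 (0.31 log units; beyond the scatter) on going to methyl. Neither involves methoxy, so this step has no direct measurement behind it. Judging by the modest at least 2.0-fold lower number from compound 2 to compound 3 (0.31 log units; beyond the scatter) at this carbon, no step beyond the scatter is expected in this assay here. The estimated change is a 1.1-fold higher number from compound 3 to compound 4 (0.05 log units; within the scatter) in this case. Compound 4 is estimated at 320000 nM with an expected range from 140000 nM to 650000 nM in this test.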

Compound 4, concentration for 50% growth inhibition: > 659000 nM
Compound 4: only a limit was reported; the forecaster's own chance of this, stated with the estimate: 30%; middle value at least 2.0-fold (0.31 log units) from the limit.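

At this carbon, methoxy does not hold the reading that methyl gave: in this assay the change brings an at least 2.3-fold higher number from compound 3 to compound 4 (0.36 log units; beyond the scatter). Of the four groups shown on this carbon, methyl alone now has a true number, while methoxy reads only as a limit, as chloro and bromo do: the limit of > 659000 nM in this assay, at which 1 of the 4 values shown sits.

The steps linking compound 4 to compound 1 and to compound 2 cannot be read. From the compounds shown here alone, whether an ethyl group or an amine on this carbon would give a lower number than methyl stays open.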